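Dithiocarbamate-linked quinazolines: a nitrophenyl step from compound 1

This account rests on a few compounds, and the source may have more. Where it says the series, first, only, none or still open, it means among the compounds named here.

The account begins with compound 1 `CN1CCN(C(=S)SCc2ccc3nc(N)nc(N)c3c2)CC1`, which in a functional assay on A549 cells (Homo sapiens) for antiproliferative activity, read by MTT assay, with a stated time of 72 h (a higher number here means a weaker inhibitor, a lower number a stronger inhibitor), gives 9200 nM, the highest of the three numbers recorded. Compound 2 `COc1ccc(N2CCN(C(=S)SCc3ccc4nc(N)nc(N)c4c3)CC2)cc1` gives 1590 nM, and compound 3 `Nc1nc(N)c2cc(CSC(=S)N3CCN(c4ccc(F)cc4F)CC3)ccc2n1` gives 5120 nM. Compound 4 `Nc1nc(N)c2cc(CSC(=S)N3CCN(c4ccccc4[N+](=O)[O-])CC3)ccc2n1` is not yet measured; it differs from compound 1 in one place: 2-nitrophenyl in place of methyl on an amine nitrogen in a ring. Among the compounds with values here, two measured steps bear on this change, both replacing the same methyl by an aryl group on the ring nitrogen. The change a 5.8-fold lower number from compound 1 to compound 2 (0.76 log units; beyond the scatter) was beyond the scatter, while a 1.8-fold lower number from compound 1 to compound 3 (0.25 log units; within the scatter) stayed within it, and between the two aryl groups a 3.2-fold higher number from compound 2 to compound 3 (0.51 log units; beyond the scatter) was seen. Both aryl replacements lowered the number, but by different amounts, so the aryl group itself appears to matter, with compound 3 showing the smaller effect. On this basis a modest lowering is expected for compound 4, of the order of a 2.3-fold lower number from compound 1 to compound 4 (0.36 log units; beyond the scatter). Compound 4 is therefore estimated at 4000 nM, with a range from 1500 nM to 10000 nM.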

Compound 4, half-maximal inhibitory concentration: 4360 nM
Compound 4: middle estimate off by 1.1-fold (0.04 log units), on the low side; the measured number falls inside the stated range.
By their numbers in this assay, from the lowest: compound 2; then compounds 4, 3 and 1 (each within the scatter of the next, the first and the last beyond it).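

The 2-nitrophenyl group gives a second aryl replacement of the methyl with a step beyond the scatter, a 2.1-fold lower number from compound 1 to compound 4 (0.32 log units; beyond the scatter), joining the 4-methoxyphenyl of compound 2, while the 2,4-difluorophenyl of compound 3 goes against any general gain from an aryl group at this amine nitrogen. The two aryl groups in compounds 3 and 4 cannot be told apart, as a 1.2-fold lower number from compound 3 to compound 4 (0.07 log units; within the scatter) stays within the scatter, whereas the 4-methoxyphenyl group stays apart from the 2-nitrophenyl group, with a 2.7-fold higher number from compound 2 to compound 4 (0.44 log units; beyond the scatter). No measurement accompanies these compounds that could account for the differences among the aryl groups.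

The compounds shown leave open how a 4-nitrophenyl group on the same nitrogen would compare with the 2-nitrophenyl group. They also leave open how a benzyl group or an acetyl group there would read.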